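Methyl to ethyl on a piperazine nitrogen: expected cytotoxicity

The source may hold more compounds than are shown below. What is called first, only, known or untested is meant among the compounds shown, and "the series" means these compounds.

Measured compounds:
compound 1, `N#Cc1ccc(Nc2nc(Oc3ccnc4ccccc34)nc(N3CCN(c4ccccc4Cl)CC3)n2)cc1C(F)(F)F`, 92600 nM
compound 2, `CC1CC(C)CN(c2nc(Nc3ccc(C#N)c(C(F)(F)F)c3)nc(Oc3ccnc4ccccc34)n2)C1`, 27200 nM
compound 3, `CN1CCN(c2nc(Nc3ccc(C#N)c(C(F)(F)F)c3)nc(Oc3ccnc4ccccc34)n2)CC1`, 51200 nM

The three compounds share a core and differ only in the saturated ring attached to it. They were tested in a functional assay on DU-145 cells (Homo sapiens) for cytotoxicity, read by sulforhodamine B assay, with a stated time of 48 h; on this read-out lower numbers stand for stronger inhibition of growth and higher numbers for weaker inhibition of growth. Compound 3 gives 51200 nM; it is separated from compound 1 by a 1.8-fold lower number from compound 1 to compound 3 (0.26 log units; within the scatter) and from compound 2 by a 1.9-fold higher number from compound 2 to compound 3 (0.27 log units; within the scatter), so neither neighbour is distinguishable from it on this read-out.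

Compound 4, `CCN1CCN(c2nc(Nc3ccc(C#N)c(C(F)(F)F)c3)nc(Oc3ccnc4ccccc34)n2)CC1`, is not yet measured. It differs from compound 3 by methyl in place of hydrogen on a saturated chain carbon bound to an amine nitrogen in a ring, that is, methyl to ethyl, or 4-methylpiperazin-1-yl to 4-ethylpiperazin-1-yl. The closest measured step is the one that changed the substituent on the same ring nitrogen, a 1.8-fold lower number from compound 1 to compound 3 (0.26 log units; within the scatter), and the change of the whole ring, a 1.9-fold higher number from compound 2 to compound 3 (0.27 log units; within the scatter), was also within the scatter. A single added carbon at this place is therefore expected to give a step of a 1.1-fold lower number from compound 3 to compound 4 (0.06 log units; within the scatter) in this assay, nothing beyond the scatter in either direction. Compound 4 is estimated at 45000 nM, with a likely range from 15000 nM to 130000 nM.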

Compound 4, concentration for 50% growth inhibition: 86600 nM
Estimate against measurement, compound 4: 1.9-fold (0.28 log units) below; the range from low to high includes it.
By their numbers in this assay, from the lowest: compounds 2, 3, 4 and 1 (each within the scatter of the next, the first and the last beyond it).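

In this assay, one added carbon on the amine nitrogen in the ring gives a 1.7-fold higher number from compound 3 to compound 4 (0.23 log units; within the scatter) and so does not separate ethyl from methyl on this read-out. Ethyl is also not separated from the much larger 2-chlorophenyl on that nitrogen, with a 1.1-fold lower number from compound 1 to compound 4 (0.03 log units; within the scatter), while replacing 3,5-dimethylpiperidin-1-yl with 4-ethylpiperazin-1-yl gives a 3.2-fold higher number from compound 2 to compound 4 (0.50 log units; beyond the scatter), the first modest step in this small set that lies beyond the scatter. No measurement shown here explains these numbers.

On these data alone, it remains open whether a longer chain such as propyl on this nitrogen would give a step beyond the scatter from compound 4. The same question stands for a chain ending in an amine or a carboxylic acid.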